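A few compounds are considered here, and "the series" means these few. Any claim that something is new, unique, unknown or untested is made for them only; others in the source may bear on it.

Measured so far:
- compound 1, `Cc1ccccc1/C=N/NC(N)=S`, 3400 nM
- compound 2, `NC(=S)N/N=C/c1ccccc1Cl`, 1400 nM

Both compounds were tested in a functional assay on B16 cells (Mus musculus) for inhibition; on this read-out lower numbers stand for stronger inhibition and higher numbers for weaker inhibition. Among the compounds with values here, compound 2 stands at the lower of the two numbers, so the stronger inhibitor of the pair; its only neighbour is compound 1, and a 2.4-fold lower number from compound 1 to compound 2 (0.39 log units; beyond the scatter) separates them, a difference that is beyond the usual scatter of this kind of measurement.

The next compound, compound 3, is `COc1ccccc1/C=N/NC(N)=S`. It arises from compound 2 by one change: methoxy in place of chloro on an aromatic carbon.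

Within the data shown here, only one measured step exists, and it concerns a different replacement, chloro in place of methyl. It shows that a change at this position can move the number by a modest amount, as seen in a 2.4-fold lower number from compound 1 to compound 2 (0.39 log units; beyond the scatter), but it gives no direct information on what methoxy does there. Among the measured compounds shown here, no step with methoxy has been measured. The expectation is therefore a cautious one: a step in this assay that could go either way, likely of modest size, so the estimated value for compound 3 is 2500 nM, within a range from 900 nM to 7000 nM, which means an expected step of a 1.8-fold higher number from compound 2 to compound 3 (0.25 log units; within the scatter).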

Compound 3, half-maximal inhibitory concentration: 16100 nM
Compound 3: middle estimate off by 6.4-fold (0.81 log units), on the low side; the measured number lies above the stated range.
By their numbers in this assay, from the lowest: compound 2; then compound 1; then compound 3.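

Read in this assay, the swap of methoxy for chloro gives a 12-fold higher number from compound 2 to compound 3 (1.06 log units; beyond the scatter) and so shows that the group on this aromatic carbon can shift the number by far more than the only earlier step suggested. Methoxy also compares poorly with methyl, with a 4.7-fold higher number from compound 1 to compound 3 (0.68 log units; beyond the scatter) as the printed step, so the order from stronger to weaker inhibition among these three groups is chloro, then methyl, then methoxy, and each gap in that order lies beyond the scatter. Nothing measured here explains why methoxy gives so much weaker inhibition than the other two groups.

Within the data shown here, the three compounds cover only three small groups at a single place on the ring, so it remains open how an amine, a hydroxyl group, a carboxylic acid or a longer chain such as ethoxy would behave on this same carbon. As far as these compounds go, it is also open whether the order of chloro, methyl and methoxy would hold if these groups sat on a different carbon of the ring, or whether plain hydrogen would beat all three.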